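A few compounds are considered here, and "the series" means these few. Any claim that something is new, unique, unknown or untested is made for them only; others in the source may bear on it.

Measured compounds:
- compound 1 `COc1ccc(C(=O)/C=C/c2ccc(C(=O)N3CCCC3)cc2)c(O)c1`: > 100000 nM
- compound 2 `CCOCCCOc1ccc(/C=C/C(=O)c2ccc(OC)cc2O)cc1OC`: > 100000 nM
- compound 3 `COc1ccc(C(=O)/C=C/c2cc(Br)c(OCc3ccccc3)c(OC)c2)c(O)c1`: > 100000 nM

In an ADME assay on SH-SY5Y cells (Homo sapiens) for cytotoxicity, read by MTT assay, with a stated time of 48 h (a higher number here means a weaker inhibitor, a lower number a stronger inhibitor), compound 1 gives only a limit of the assay, > 100000 nM, and not a number. For compound 2 the same assay likewise reports only a limit, > 100000 nM. For compound 3 the value in this assay is again a limit, > 100000 nM. For the measured compounds named here, all three measured values therefore sit together, as the limit of > 100000 nM in this assay, at which 3 of the 3 values shown sit, shows, and no step between measured compounds can be read off.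

The unmeasured compound 4 `COc1ccc(C(=O)/C=C/c2ccc(C(=O)Nc3ccc(C)cc3C)cc2)c(O)c1` is reached from compound 1 by one change, (2,4-dimethylphenyl)amino in place of pyrrolidin-1-yl on a carbonyl carbon. Since every value shown is a limit, the step from compound 1 to compound 4 in this assay is expected to be none beyond the scatter, and most likely compound 4 will again reach only the limit. The step of a number no higher from compound 1 to compound 4 (the limit leaves the size open) is the one this estimate means. Compound 4 is expected to give about 100000 nM, in a range from 30000 nM to 300000 nM.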

Compound 4, half-maximal inhibitory concentration: > 100000 nM
Compound 4: a limit, no number (the forecaster's own chance of this, stated with the estimate: 85%); the middle value lies on the limit itself.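

In this assay, for the compounds shown here, neither compound 1 nor compound 4 yields a number, so no step between them can be read: the limit of > 100000 nM in this assay, at which 4 of the 4 values shown sit.

The compounds shown leave open what half-maximal inhibitory concentration any of them would reach in this assay and whether (2,4-dimethylphenyl)amino in place of pyrrolidin-1-yl changes it at all.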